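Sulfonyl substituent exchange on the compound 1 core

A few compounds are considered here, and "the series" means these few. Any claim that something is new, unique, unknown or untested is made for them only; others in the source may bear on it.

Three compounds measured in an assay for binding affinity to adenosine receptor A1 (Bos taurus) (a higher number here means a weaker inhibitor, a lower number a stronger inhibitor), frame the series. Compound 1 `CCn1c(=O)c2nc(-c3cccc(S(=O)(=O)NCCN(C)C)c3)[nH]c2n(CC)c1=O` gives 29.4 nM, the highest of the three numbers. Going by the values given here, compound 2 `Cn1c(=O)c2nc(-c3cccc(F)c3)[nH]c2n(C)c1=O` gives 4 nM, and compound 3 `CCCn1c(=O)c2nc(-c3ccc(S(=O)(=O)NCCCC(=O)OCC)cc3)[nH]c2n(CCC)c1=O` gives 0.24 nM; the gaps from compound 1 to both lie beyond the scatter, so compound 1 is the weakest of the three measured so far.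

The step under consideration goes to compound 4 `CCn1c(=O)c2nc(-c3cccc(S(=O)(=O)O)c3)[nH]c2n(CC)c1=O`. The change is hydroxy in place of (2-(dimethylamino)ethyl)amino on a sulfonyl sulfur. Among the compounds with values here, no measured pair covers this kind of exchange, so there is no directly comparable step to lean on. Compound 2 and compound 3 carry different substituents on different cores and do not isolate the sulfonyl change.

Without a reference step, the expected step from compound 1 to compound 4 is a 1.7-fold higher number from compound 1 to compound 4 (0.23 log units; within the scatter), a modest move toward a higher number that may still fall within the scatter. Compound 4 is estimated at 50 nM, with a range from 10 nM to 250 nM.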

Compound 4, half-maximal inhibitory concentration: 8420 nM
Compound 4: the middle estimate sits 170-fold (2.23 log units) below what was measured; measured number above the stated range.
By their numbers in this assay, from the lowest: compound 3; then compound 2; then compound 1; then compound 4.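

In this assay, going by these compounds alone, the sulfonyl sulfur proves sensitive to what it carries: hydroxy in place of (2-(dimethylamino)ethyl)amino gives a 290-fold higher number from compound 1 to compound 4 (2.46 log units; beyond the scatter) and provides the first step that isolates a single change. This substituent therefore cannot be exchanged freely on the core of compound 1, which compound 2 and compound 3 could not show. Nothing available explains the size of this step.

On these data alone, whether the loss follows from removing the (2-(dimethylamino)ethyl)amino chain or from introducing hydroxy remains open; an unsubstituted sulfonamide amine, a longer aminoalkyl chain or a chain ending in a carboxylic acid would help separate the two. Also open, as far as these compounds go, is whether the same exchange behaves alike on the core of compound 3.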